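A few compounds are considered here, and "the series" means these few. Any claim that something is new, unique, unknown or untested is made for them only; others in the source may bear on it.

Measured in a functional assay on NCI/ADR-RES cells (Homo sapiens) for antiproliferative activity, read by sulforhodamine B assay, with a stated time of 48 h; on this read-out higher numbers stand for weaker inhibition of growth and lower numbers for stronger inhibition of growth:
- compound 1 `CCCCCC[C@@H](O)C/C=C\CCCCCCCC(=O)N[C@@H](C)c1ccccc1` gives 1.9 ug/mL
- compound 2 `CCCCC/C=C\C/C=C\CCCCCCCC(=O)N1CCCCC1` gives 63.2 ug/mL

Of these two, compound 1 has the lower number, and the gap to compound 2 lies beyond the scatter. Compound 3 `CCCCCC[C@@H](O)C/C=C\CCCCCCCC(=O)N1CCOCC1` is the next to be read against compound 1, with this change: morpholin-4-yl in place of (1-phenylethyl)amino on a carbonyl carbon. Compound 2 also has no amide hydrogen and stands at 63.2 ug/mL, but it differs from compound 1 elsewhere too, so it is only a loose guide. A rise beyond the scatter is expected in this assay, estimated as a 7.9-fold higher number from compound 1 to compound 3 (0.90 log units; beyond the scatter). For compound 3 the expected value is 15 ug/mL, with an estimated range of 4 ug/mL to 60 ug/mL.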

Compound 3, concentration for 50% growth inhibition: 29.4 ug/mL
Compound 3: middle estimate off by 2.0-fold (0.29 log units), on the low side; the range from low to high includes it.
By their numbers in this assay, from the lowest: compound 1; then compound 3; then compound 2.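

With the rest of compound 1 unchanged, morpholin-4-yl in place of (1-phenylethyl)amino on the carbonyl carbon gives a 15-fold higher number from compound 1 to compound 3 (1.19 log units; beyond the scatter) in this assay, so this position alone has a large effect on the read-out. The change removes the aromatic ring, the amide hydrogen and the stereocentre of the group together, so this single step cannot separate them. Nothing available accounts for the size of the step.

Open, going by these compounds, is whether benzylamino, which lacks that stereocentre, or cyclohexylamino, which keeps the amide hydrogen without the aromatic ring, would stay close to compound 1 at this carbonyl carbon.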